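Swapping one dichlorophenyl isomer for another

The source may report more compounds than this note shows. Statements on the series, on what has been measured and on what is new or still open speak of the compounds shown alone.

In an ADME assay on HCT-116 cells (Homo sapiens) for cytotoxicity, read by CellTiter-Glo, with a stated time of 72 h (a higher number here means a weaker inhibitor, a lower number a stronger inhibitor), compound 3 (`CC1CCN(C2CCN(S(=O)(=O)c3ccc(Cl)c(Cl)c3)CC2)CC1`) gives > 5000 nM as a limit and not a number. Compound 1 (`CC1CCN(C2CCN(S(=O)(=O)c3ccccc3Br)CC2)CC1`) gives > 5000 nM as a limit too. Compound 2 (`CCc1ccc(S(=O)(=O)N2CCC(N3CCC(C)CC3)CC2)cc1`) gives > 5000 nM as a limit as well. All the results so far therefore stand at the limit of > 5000 nM in this assay, at which 3 of the 3 values shown sit, and none is an exact number.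

Compound 4 (`CC1CCN(C2CCN(S(=O)(=O)c3ccc(Cl)cc3Cl)CC2)CC1`) has the same atoms as compound 3, joined differently, with 2,4-dichlorophenyl in place of 3,4-dichlorophenyl on a sulfonyl sulfur.

The closest guides are the other swaps on that sulfur: a step that the two limits leave unreadable from compound 1 to compound 3 and a step that the two limits leave unreadable from compound 2 to compound 3 and a step that the two limits leave unreadable from compound 1 to compound 2 as well. None of these has a size that can be carried over, so no step beyond the scatter is expected in this assay in either direction. The expected change is a step that the limit leaves unreadable from compound 3 to compound 4 and it has no expected direction. Compound 4 will most likely report the same limit, and as a number it is estimated at 8000 nM with an expected range from 4000 nM to 20000 nM here.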

Compound 4, half-maximal inhibitory concentration: > 5000 nM
Compound 4: no number, only a limit (the forecaster's own chance of this, stated with the estimate: 90%); the middle value lies beyond the limit too.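

Compound 4 can be set against compound 1, compound 2 and compound 3 in this assay only through limits and not numbers, so none of these steps can be read: the limit of > 5000 nM in this assay, at which 4 of the 4 values shown sit.

From the compounds shown here alone, whether the groups on the sulfonyl sulfur of these four compounds differ at all in this assay stays open.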